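The compounds below may be only part of what the source reports. "The series", "measured", "known", "first", "only" and "open" are said of these compounds alone.

Compound 1 `CCOC(=O)c1ccc(-c2ccc(OCC)cc2)o1`: 93%
Compound 2 `CCOC(=O)c1cccc(-c2ccc(CN(C)C)cc2)c1`: 67%
Compound 3 `CCOc1ccc(-c2cccc(C(=O)O)c2)cc1`: 23%

In an assay on COS-7 cells for inhibition of patatin-like phospholipase domain-containing protein 2 (Mus musculus), tested at 200 uM (on this read-out higher numbers stand for more inhibition at the one concentration tested (going by the name of the read-out) and lower numbers for less inhibition), compound 1 gives 93%, compound 2 gives 67% and compound 3 gives 23%. Compound 3 stands lowest of the three. Its nearest neighbour is compound 2, whose number is higher by a margin beyond the scatter, and compound 1 lies furthest above it, again beyond the scatter. No pair among these three differs in a single place, so the numbers say only where each compound stands, not what any one change does.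

Compound 4 `CCOc1ccc(-c2cccc(C(=O)N3CCCC3)c2)cc1` has not yet been tested in this assay. It differs from compound 3 in one place: pyrrolidin-1-yl in place of hydroxy on a carbonyl carbon. Going by the values given here, there is no measured pair that makes this same change, so the expectation rests on the spread of the three numbers. Both compounds that carry no hydroxy on a carbonyl carbon score higher than compound 3, which is the only one that does. On that basis compound 4 is expected to rise above compound 3 by a step beyond the scatter, a number 32 percentage points higher from compound 3 to compound 4 (beyond the scatter), though the size is uncertain. Compound 4 is estimated at 55%, with a range from 30% to 80%.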

Compound 4, a percentage reported as inhibition, at one concentration (the size of the read-out at that concentration, not a potency): 53%
Beside the measured number, compound 4's estimate is 2 percentage points above it, within the range that was stated.
By their numbers in this assay, from the lowest: compound 3; then compound 4; then compound 2; then compound 1.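

In this assay, going by these compounds alone, the change on the carbonyl carbon gives a number 30 percentage points higher from compound 3 to compound 4 (beyond the scatter), the first comparison in this set that isolates a single place. Within the data shown here, it shows that the read-out responds to what sits on this carbonyl carbon, which the earlier compounds, differing in more than one place, could only rank and not resolve. The step is a single pair, and the change alters several counted features at once: a hydroxy with its hydrogen-bond donor leaves, and pyrrolidin-1-yl enters with five heavy atoms, a five-membered non-aromatic ring and no donor, so the pair cannot say which of these features matters. Nothing available here bears on why the number moves with this change.

As far as these compounds go, it remains open whether an open-chain diethylamino group, a six-membered piperidin-1-yl ring or a plain unsubstituted amide on the same carbonyl carbon would give a number close to that of compound 4. From the compounds shown here alone, it also remains open whether replacing carboxy with (pyrrolidin-1-yl)carbonyl would produce a step of similar size on a different core.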